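Cytotoxicity of anilides on a shared hydroxyquinoline core

This account rests on a few compounds, and the source may have more. Where it says the series, first, only, none or still open, it means among the compounds named here.

Compound 1 `Cc1ccccc1NC(=O)c1ccc2cccc(O)c2n1` in an ADME assay on THP-1 cells (Homo sapiens) for cytotoxicity, read by WST assay, with a stated time of 24 h (on this read-out higher numbers stand for weaker inhibition and lower numbers for stronger inhibition), gives > 30000 nM, a limit of the assay.
Compound 2 `O=C(Nc1cccc(F)c1)c1ccc2cccc(O)c2n1` in this assay gives > 30000 nM, also a limit.

Compound 2 thus stands at the limit of the assay, where both values shown sit (the limit of > 30000 nM in this assay, at which 2 of the 2 values shown sit). For the measured compounds named here, the only measured step, a step that the two limits leave unreadable from compound 1 to compound 2, cannot be sized. The change to compound 3 `O=C(Nc1ccccc1Cl)c1ccc2cccc(O)c2n1` is 2-chlorophenyl in place of 3-fluorophenyl on an amide-type nitrogen. No readable step bears on this change. Compound 3 is therefore expected to remain at the limit, a step that the limit leaves unreadable from compound 2 to compound 3 that means no shift beyond the scatter. The estimate for compound 3 is 45000 nM, between 15000 nM and 150000 nM.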

Compound 3, half-maximal inhibitory concentration: > 30000 nM
Compound 3 ended at the assay's limit; the forecaster's own chance of this, stated with the estimate: 85%; the middle value does not contradict the limit.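

In this assay no new step can be read among compound 1, compound 2 and compound 3, since all three sit at one limit: the limit of > 30000 nM in this assay, at which 3 of the 3 values shown sit.

As far as these compounds go, whether these three compounds differ from one another at all in this assay stays open.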